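A few compounds are considered here, and "the series" means these few. Any claim that something is new, unique, unknown or untested is made for them only; others in the source may bear on it.

Compound 1 `O=C(CCc1cccc2c1B(O)OC2)Nc1cccc(Br)c1`: 540 nM
Compound 2 `O=C(CCc1cccc2c1B(O)OC2)Nc1cccc(-c2cccc(Cl)c2)c1`: 300 nM
Compound 3 `O=C(CCc1cccc2c1B(O)OC2)Nc1cccc(-c2ccc(Cl)cc2)c1`: 220 nM

In a functional assay on SK-OV-3 cells (Homo sapiens) for antiproliferative activity, read by MTT assay, with a stated time of 72 h (on this read-out higher numbers stand for weaker inhibition and lower numbers for stronger inhibition), two steps place compound 3: a 1.4-fold lower number from compound 2 to compound 3 (0.13 log units; within the scatter), and a 2.5-fold lower number from compound 1 to compound 3 (0.39 log units; beyond the scatter). It therefore stands level with compound 2 and modestly clear of compound 1.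

Compound 4 `O=C(CCc1cccc2c1B(O)OC2)Nc1cccc(-c2ccc(OC(F)(F)F)cc2)c1` carries trifluoromethoxy in place of chloro, para to a large group (trifluoromethoxy in place of chloro on an aromatic carbon). Among the compounds with values here, no measured step makes this exact swap. The nearest measured change is a 1.4-fold lower number from compound 2 to compound 3 (0.13 log units; within the scatter), which puts 4-chlorophenyl in place of 3-chlorophenyl, so no step beyond the scatter is expected in this assay. The expected change is a 1.1-fold higher number from compound 3 to compound 4 (0.06 log units; within the scatter). Compound 4 is estimated at 250 nM, with an expected range of 100 nM to 600 nM.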

Compound 4, half-maximal inhibitory concentration: 560 nM
Compound 4: the middle estimate sits 2.2-fold (0.35 log units) below what was measured; the measured number falls inside the stated range.
By their numbers in this assay, from the lowest: compounds 3, 2, 1 and 4 (each within the scatter of the next, the first and the last beyond it).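

In this assay the change from chloro to trifluoromethoxy, para to a large group, gives a 2.5-fold higher number from compound 3 to compound 4 (0.41 log units; beyond the scatter), whereas the earlier swap of 3-chlorophenyl for 4-chlorophenyl gave only a 1.4-fold lower number from compound 2 to compound 3 (0.13 log units; within the scatter). The identity of the group on this aromatic carbon can therefore move the number beyond the scatter. Nothing measured here gives a reason for this step. The compounds shown leave open how an amine, a carboxylic acid or a methyl group would read at this place, and whether any of them would match chloro.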